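This account rests on a few compounds, and the source may have more. Where it says the series, first, only, none or still open, it means among the compounds named here.

In a physicochemical assay for solubility, in phosphate buffer, measured as kinetic solubility, with a stated time of 24 h, at pH 6.5 (a lower number here means a less soluble compound, a higher number a more soluble compound), compound 1 `CC(C)Oc1cc(Oc2cnc(C(=O)N(C)C)nc2)cc(-c2nccc(=O)[nH]2)c1` gives 332000 nM and compound 3 `CCC(CC)Oc1cc(Oc2cnc(C(=O)N(C)C)nc2)cc(-c2nccc(=O)[nH]2)c1` gives 469000 nM, two values within the scatter of each other. Among the compounds with values here, compound 2 `COc1cnc(-c2cc(Oc3ccc(S(C)(=O)=O)cc3)cc(OC(C)C)c2)[nH]c1=O` gives a much lower number, 7100 nM, and no single-place step links it to the other two. Compound 3 therefore stands at the top of these numbers, level with compound 1.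

Compound 4 `CN(C)C(=O)c1ncc(Oc2cc(OC3CCCC3)cc(-c3nccc(=O)[nH]3)c2)cn1` has not yet been measured. It differs from compound 3 in one place: cyclopentyl in place of pentan-3-yl on an oxygen on an aromatic ring. The open chain gives way to a five-membered non-aromatic ring of carbon only, still on an oxygen on an aromatic ring.

Within the data shown here, one measured step bears on this place: a 1.4-fold higher number from compound 1 to compound 3 (0.15 log units; within the scatter), with pentan-3-yl in place of isopropyl on that oxygen. Among the measured compounds shown here, no measured step shows what a ring does here, so this guide is indirect. With that small step as the precedent, no shift beyond the scatter is expected, and the estimated step is a 1.2-fold lower number from compound 3 to compound 4 (0.07 log units; within the scatter). For compound 4 the estimated value is 400000 nM, with an expected range of 170000 nM to 800000 nM.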

Compound 4, solubility: 398000 nM
The estimate for compound 4 lay 1.0-fold (0.00 log units) above the measured number; the range from low to high includes it.
By their numbers in this assay, from the lowest: compound 2; then compounds 1, 4 and 3 (each within the scatter of the next).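

In this assay, the first ring at this position leaves the read-out level with the open chain it replaces: cyclopentyl in place of pentan-3-yl gives a 1.2-fold lower number from compound 3 to compound 4 (0.07 log units; within the scatter), and cyclopentyl in place of isopropyl gives a 1.2-fold higher number from compound 1 to compound 4 (0.08 log units; within the scatter). The earlier compounds had shown only open chains on this oxygen, whereas isopropyl, pentan-3-yl and cyclopentyl now all lie within the scatter of one another. Nothing measured here accounts for this result.

The compounds shown leave open what happens when this oxygen carries a group that is not carbon only, such as an amine or a carboxylic acid, or a larger ring such as cyclohexyl. Within the data shown here, compound 2, at 7100 nM, is linked to the others by no single-place step, so the origin of its distance from them remains unresolved.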